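The compounds below may be only part of what the source reports. "The series", "measured", "known", "first", "only" and "open" are said of these compounds alone.

Measured so far:
Compound 1, `Cc1cc(Cl)ccc1OCc1nnc(-c2ccccc2C(F)(F)F)o1`, in an ADME assay on cells for inhibition of anoctamin-2 (Homo sapiens), read by fluorescence, with a stated time of 20 min; a lower number here means a stronger inhibitor, a higher number a weaker inhibitor: > 100000 nM, a limit of the assay, not a number.
Compound 2, `Cc1cc(Cl)ccc1OCc1nnc(-c2ccco2)o1`, in this assay: > 100000 nM, likewise a limit.

Among the measured compounds shown here, compound 1 stands at the limit; the only evidence in hand is the limit of > 100000 nM in this assay, at which 2 of the 2 values shown sit. For the measured compounds named here, no step between measured compounds can be read from this. Compound 3, `Cc1cc(Cl)ccc1OCc1nnc(-c2ccccc2OC(F)(F)F)o1`, differs from compound 1 by trifluoromethoxy in place of trifluoromethyl on an aromatic carbon. Given (the limit of > 100000 nM in this assay, at which 2 of the 2 values shown sit), no step in this assay beyond the scatter is expected in either direction, and a limit is again the most probable report. The estimate for compound 3 is 150000 nM, with an expected range from 30000 nM to 700000 nM. That estimate means an expected step that the limit leaves unreadable from compound 1 to compound 3.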

Compound 3, half-maximal inhibitory concentration: "not active" (no number reported)
Compound 3: no number reported, so the estimate cannot be set against anything.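

Among the compounds shown here, compound 3 carries no number in this assay, so no step from compound 1 to compound 3 can be read. The compounds shown leave open which change to the shared core, if any, would give a measurable value in this assay.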